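Chloro to Methoxy: Predicting Compound 4

A few compounds are considered here, and "the series" means these few. Any claim that something is new, unique, unknown or untested is made for them only; others in the source may bear on it.

In a functional assay on RS4-11 cells (Homo sapiens) for inhibition, read by CCK-8 assay, with a stated time of 48 h (a lower number here means a stronger inhibitor, a higher number a weaker inhibitor), three compounds have been tested. Compound 1 `COc1cccc(NC(=S)NCCNS(=O)(=O)c2ccc(-c3ccccc3Oc3ccc([N+](=O)[O-])cc3)s2)c1` gives only a limit, > 50000 nM. Compound 2 `O=[N+]([O-])c1ccc(Oc2ccccc2-c2ccc(S(=O)(=O)NCCNC(=S)Nc3cccc(Cl)c3)s2)cc1` likewise gives only a limit, > 50000 nM. The two share a core and differ by methoxy in place of chloro on an aromatic carbon, giving a step that the two limits leave unreadable from compound 2 to compound 1; this is tied to the limit of > 50000 nM in this assay, at which 2 of the 3 values shown sit. Among the measured compounds shown here, compound 3 `O=C(NCCNS(=O)(=O)c1ccc(-c2ccccc2Oc2ccc([N+](=O)[O-])c([N+](=O)[O-])c2)s1)Nc1ccc(Cl)cc1` is the one compound with a number, 6700 nM, and how its core differs from that of compound 2 is not broken down here. Compound 4 `COc1ccc(NC(=O)NCCNS(=O)(=O)c2ccc(-c3ccccc3Oc3ccc([N+](=O)[O-])c([N+](=O)[O-])c3)s2)cc1` has not yet been measured; it differs from compound 3 by methoxy in place of chloro on an aromatic carbon. The same kind of change was made from compound 2 to compound 1, but there the group sits meta to a large group, while here it sits para to a large group. Since that earlier step is unreadable, the expectation rests on the value of compound 3, 6700 nM, and on a change of this kind being expected to shift it little: the estimated step is a 1.2-fold higher number from compound 3 to compound 4 (0.08 log units; within the scatter). Compound 4 is therefore estimated at 8000 nM, between 2500 nM and 25000 nM.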

Compound 4, half-maximal inhibitory concentration: 1400 nM
The estimate for compound 4 lay 5.7-fold (0.76 log units) above the measured number; the measured number lies below the stated range.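

In this assay, methoxy in place of chloro, on an aromatic carbon para to a large group, gives a 4.8-fold lower number from compound 3 to compound 4 (0.68 log units; beyond the scatter), so on this core the change goes with a stronger inhibitor, by a step beyond the usual scatter. This does not show that the gain carries over to another core, since the same change on the core shared by compound 2 and compound 1 cannot be read, because both compounds give a limit and not a number: the limit of > 50000 nM in this assay, at which 2 of the 4 values shown sit. The two pairs also carry the group at different places on the ring, so one readable step gives no rule for the series.

The compounds shown leave open how an amine or a carboxylic acid at that same place would compare with the chloro of compound 3 and the methoxy of compound 4. They also leave open whether the change holds on a further core where both partners give numbers rather than limits.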